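From a Phenyl to a 4-Fluorobenzyl on the Indole Nitrogen

The compounds below may be only part of what the source reports. "The series", "measured", "known", "first", "only" and "open" are said of these compounds alone.

The shared core carries a chain ending in an ester, attached through a double bond, and a group on an aromatic nitrogen. Compound 1 `C/C=C/Cn1cc(/C=C/C(=O)CC(=O)C(=O)OCC)c2ccccc21` bears a but-2-en-1-yl group there. In an assay on isolated protein for inhibition of DNA nucleotidylexotransferase (Homo sapiens), read by scintillation counting, with a stated time of 10 min (a higher number here means a weaker inhibitor, a lower number a stronger inhibitor), compound 1 gives > 40 uM, which is a limit of the assay rather than a number. Compound 2 `CCOC(=O)C(=O)CC(=O)/C=C/c1cn(-c2ccccc2)c2ccccc12` carries a phenyl on the same nitrogen. In this assay compound 2 gives > 40 uM, again a limit and not a measured number. The step from compound 1 to compound 2 is therefore a step that the two limits leave unreadable from compound 1 to compound 2, and compound 2 stands only at a limit, as the limit of > 40 uM in this assay, at which 2 of the 2 values shown sit, shows.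

Compound 3 `CCOC(=O)C(=O)CC(=O)/C=C/c1cn(Cc2ccc(F)cc2)c2ccccc12` differs from compound 2 by 4-fluorobenzyl in place of phenyl on an aromatic nitrogen. Going by the values given here, the only measured step on this nitrogen is the one from compound 1 to compound 2, and because it is a step that the two limits leave unreadable from compound 1 to compound 2 it gives no readable size to carry over. The expected step from compound 2 to compound 3 in this assay is therefore a step that the limit leaves unreadable from compound 2 to compound 3, with most weight on another limit. For compound 3 the estimated value in this assay is 45 uM, in a range from 12 uM to 150 uM.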

Compound 3, concentration for 50% inhibition: > 40 uM
Compound 3: only a limit was reported; the forecaster's own chance of this, stated with the estimate: 70%; the middle value lies beyond the limit too.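

In this assay compound 3 gives > 40 uM, which is a limit and not a number. No step among compound 1, compound 2 and compound 3 can be read, because all three stop at the same limit: the limit of > 40 uM in this assay, at which 3 of the 3 values shown sit.

The compounds shown leave open how strongly each one inhibits, and whether the group on the aromatic nitrogen matters at all.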